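The compounds below may be only part of what the source reports. "The series", "measured", "known", "first", "only" and "open" are said of these compounds alone.

Compound 1 `Cc1ccc(S(=O)(=O)NC(=O)Nc2ccccc2C(=O)/C=C/c2ccc(N(C)C)cc2)cc1` carries the shared core with a 4-(dimethylamino)phenyl on the double-bonded chain. Among the measured compounds shown here, in an ADME assay on the whole organism for cytotoxicity, with Artemia salina as the target, with a stated time of 24 h (a higher number here means that more compound is needed for the effect, a lower number that less compound is needed), compound 1 gives 38.1 ug/mL, the highest of the two numbers so far; its nearest neighbour, compound 2 `CCOc1cc(/C=C/C(=O)c2ccccc2NC(=O)NS(=O)(=O)c2ccc(C)cc2)ccc1O`, gives 19.2 ug/mL in this assay, and the step of a 2.0-fold lower number from compound 1 to compound 2 (0.30 log units; within the scatter) stays within the scatter, so the two read as equal.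

Compound 3 `Cc1ccc(S(=O)(=O)NC(=O)Nc2ccccc2C(=O)/C=C/c2ccc(Cl)cc2)cc1` is not yet measured. Its difference from compound 1 is chloro in place of dimethylamino on an aromatic carbon, on the same aromatic carbon where compound 2 also departs from compound 1. For the measured compounds named here, only that step bears on it; it replaced the whole 4-(dimethylamino)phenyl without a change beyond the scatter, which gives no ground to expect a larger move for the smaller exchange to chloro. For compound 3 the expected step in this assay is a 1.3-fold lower number from compound 1 to compound 3 (0.10 log units; within the scatter), essentially none beyond the scatter. Compound 3 is thus estimated at 30 ug/mL, within 12 ug/mL to 80 ug/mL.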

Compound 3, concentration for half-maximal effect: 6.92 ug/mL
The estimate for compound 3 lay 4.3-fold (0.64 log units) above the measured number; the measured number lies below the stated range.
By their numbers in this assay, from the lowest: compound 3; then compounds 2 and 1 (each within the scatter of the next).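

In this assay, among the compounds shown here, chloro in place of dimethylamino on this aromatic carbon gives the first step beyond the scatter (a 5.5-fold lower number from compound 1 to compound 3 (0.74 log units; beyond the scatter)), so the position responds to a change of its group, which the earlier step between compounds 1 and 2 did not show. The 4-chlorophenyl also separates from the 3-ethoxy-4-hydroxyphenyl (a 2.8-fold lower number from compound 2 to compound 3 (0.44 log units; beyond the scatter)), which leaves compound 3 with the lowest number of the three, with both of its steps beyond the scatter. Nothing measured here accounts for this shift.

With one halogen and one amine at this position, the compounds shown cannot tell whether the step follows from the arrival of chloro or the departure of dimethylamino. Bromo, fluoro, methoxy or an unsubstituted phenyl at the same place would bear on that, and the shared core remains unexplored.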